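Methoxy in place of chloro: cytotoxicity notes

A few compounds are considered here, and "the series" means these few. Any claim that something is new, unique, unknown or untested is made for them only; others in the source may bear on it.

Compound 1 `O=C(O)c1cn(C2CC2)c2c(Cl)c(N3CCCC3)c(F)cc2c1=O` and compound 2 `COc1c(N2CCCC2)c(F)cc2c(=O)c(C(=O)O)cn(C3CC3)c12` share one core; compound 3 `Nc1c(F)c(N2CCC(N)C2)c(Cl)c2c1c(=O)c(C(=O)O)cn2C1CC1` and compound 4 `COc1c(N2CCC(N)C2)c(F)c(N)c2c(=O)c(C(=O)O)cn(C3CC3)c12` share another, and the difference between the two cores is not broken down here. In a functional assay on V79 cells (Cricetulus griseus) for cytotoxicity, read by colony formation (on this read-out lower numbers stand for stronger inhibition and higher numbers for weaker inhibition), compound 1 gives 150 ug/mL, and compound 2 gives 150 ug/mL. The change from compound 1 to compound 2 is methoxy in place of chloro on an aromatic carbon and it made a step of no change at the digits printed from compound 1 to compound 2 (within the scatter). In this assay compound 3 gives 59 ug/mL, the lowest of the three numbers, and its gap to compound 1 and to compound 2 lies beyond the scatter.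

Compound 4 differs from compound 3 by methoxy in place of chloro on an aromatic carbon. Among the measured compounds shown here, this is the same kind of change as the one from compound 1 to compound 2, but the surroundings differ: here the carbon is ortho to a 3-aminopyrrolidin-1-yl group and para to an amino group, where in compound 1 it is ortho to a pyrrolidin-1-yl group. For the measured compounds named here, only one measured instance of the change exists. For compound 4 the expected step is a 1.0-fold higher number from compound 3 to compound 4 (0.01 log units; within the scatter), which rests on the flat step no change at the digits printed from compound 1 to compound 2 (within the scatter). Compound 4 is therefore estimated at 60 ug/mL in this assay, with a range from 30 ug/mL to 130 ug/mL.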

Compound 4, half-maximal inhibitory concentration: 100 ug/mL
For compound 4 the middle estimate is 1.7-fold (0.22 log units) below the measured one, within the range that was stated.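

In this assay, methoxy in place of chloro gives a 1.7-fold higher number from compound 3 to compound 4 (0.23 log units; within the scatter), and set beside the earlier step, the change reads alike on the two cores: the same change on two cores in this assay, no change at the digits printed (within the scatter) from compound 1 to compound 2 and a 1.7-fold higher number (0.23 log units; within the scatter) from compound 3 to compound 4, 1.7-fold (0.23 log units) apart, within the scatter of two such steps

The two pairs therefore give no sign that the size of this step depends on the core, and on both cores the step stays within the scatter. Among the compounds shown here, this does not show that the change is neutral on every core of the series, since it rests on only two pairs and one read-out, and the two cores differ in more than one place, so the 3-aminopyrrolidin-1-yl and amino groups are not separated from each other here.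

The compounds shown leave open whether an ethoxy or bromo group on the same aromatic carbon would also stay within the scatter of the chloro compound on either core. They also leave open whether the step would hold with a hydroxy group in place of the amino group of compound 3 and compound 4.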